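Arylpiperazine ethers: fluorine on the aryl ring and oral inhibition

A few compounds are considered here, and "the series" means these few. Any claim that something is new, unique, unknown or untested is made for them only; others in the source may bear on it.

In a functional assay on the whole organism for inhibition, with Mus musculus as the target, at a dose of 25 mg/kg by the oral route (a lower number here means less inhibition, a higher number more inhibition at the dose given (going by the name of the read-out)), compound 1 `c1ccc(N2CCN(CCCCOc3ccc4c(c3)CCC4)CC2)cc1` gives 50%. Compound 2 `Fc1cccc(N2CCN(CCCCOc3ccc4c(c3)CCC4)CC2)c1` differs from it only by fluoro in place of hydrogen on an aromatic carbon, the place being on an aromatic carbon of a six-membered aromatic ring of carbon only, meta to a large group; in this assay compound 2 gives 17%, so the step of a number 33 percentage points lower from compound 1 to compound 2 (beyond the scatter) is a large fall, beyond the scatter. Compound 3 `c1ccc(C2CCc3ccc(OCCCN4CCN(c5ccccc5)CC4)cc32)cc1` stands on a different core; how the two cores differ is not broken down here. In this assay compound 3 gives 34%, a number beyond the scatter below that of compound 1 and above that of compound 2.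

Within the data shown here, compound 4 `Fc1ccc(N2CCN(CCCOc3ccc4c(c3)C(c3ccccc3)CC4)CC2)cc1` carries the same kind of change as the one from compound 1 to compound 2, namely (fluoro in place of hydrogen on an aromatic carbon), but here the place is para to a large group rather than meta. Among the measured compounds shown here, only one example of this change is available, and it was measured on a different core, so the expectation rests on that single step. A fall of similar kind is expected, a number 22 percentage points lower from compound 3 to compound 4 (beyond the scatter), because a number 33 percentage points lower from compound 1 to compound 2 (beyond the scatter) was large. Compound 4 is therefore estimated to give 12% in this assay, between 0% and 32%.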

Compound 4, a percentage reported as inhibition, in the whole organism at one dose (the size of the read-out at that dose, not a potency): 32%
Estimate against measurement, compound 4: 20 percentage points below; low and high end bracket the measured number.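

In this assay, the change from phenyl to 4-fluorophenyl gives a number 2 percentage points lower from compound 3 to compound 4 (within the scatter), so on the core of compound 3 the two values cannot be told apart. Fluoro in place of hydrogen on an aromatic carbon therefore cannot be carried as one fixed step from one core to the other in this series: the same change on two cores in this assay, a number 33 percentage points lower (beyond the scatter) from compound 1 to compound 2 and a number 2 percentage points lower (within the scatter) from compound 3 to compound 4, 31 percentage points apart, beyond the scatter of two such steps

This does not show that the core alone sets the size of the step, as the fluoro also sits in a different place in the two pairs, meta to a large group in compound 2 and para to a large group in compound 4, and each pair is a single example.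

Still open, on these data alone, is whether fluoro para to a large group on the core of compound 1, or meta to a large group on the core of compound 3, would follow its core or its place. Also open, as far as these compounds go, is how chloro or methoxy in these places, or a longer chain, would read in this assay.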